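The source may report more compounds than this note shows. Statements on the series, on what has been measured and on what is new or still open speak of the compounds shown alone.

Working notes on the series. Compound 1 `COc1cc(-c2nn(-c3cccc(NC(=O)c4ccc(Cl)c(C(F)(F)F)c4)c3)cc2-c2ccncc2)ccc1Cl` gives 2050 nM in a functional assay on T47D cells (Homo sapiens) for inhibition, read by sulforhodamine B assay, with a stated time of 48 h; a lower number here means a stronger inhibitor of growth, a higher number a weaker inhibitor of growth; compound 2 `COc1cc(-c2nn(-c3cccc(NC(=O)Nc4ccc(Cl)c(C(F)(F)F)c4)c3)cc2-c2ccncc2)ccc1Cl` gives 1230 nM, the lowest of the two numbers, and the step of a 1.7-fold lower number from compound 1 to compound 2 (0.22 log units; within the scatter) lies within the scatter. Compound 3 `O=C(Nc1cccc(-n2cc(-c3ccncc3)c(-c3ccc(Cl)c(O)c3)n2)c1)Nc1ccc(Cl)c(C(F)(F)F)c1` differs from compound 2 by hydrogen in place of methyl on an oxygen on an aromatic ring; no measured step touches this oxygen, so nothing shown bears on it. The expectation is therefore no step beyond the scatter, with a step of a 1.1-fold higher number from compound 2 to compound 3 (0.02 log units; within the scatter) estimated from compound 2. For compound 3 the estimate in this assay is 1300 nM, within 450 nM to 3800 nM.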

Compound 3, concentration for 50% growth inhibition: 1120 nM
The estimate for compound 3 lay 1.2-fold (0.06 log units) above the measured number, and the stated range covers the measured number.
By their numbers in this assay, from the lowest: compounds 3, 2 and 1 (each within the scatter of the next).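

Within the data shown here, compound 3 gives the first reading at this oxygen: in this assay the change from methoxy to hydroxy gives the step of a 1.1-fold lower number from compound 2 to compound 3 (0.04 log units; within the scatter) and stays within the scatter. In this single pair, the methyl on this oxygen can therefore be lost without a step beyond the scatter. Nothing at hand bears on the reason for this. Still open, going by these compounds, is whether a longer chain on this oxygen, such as ethoxy, or an amine in place of the hydroxy would move the number beyond the scatter. A single pair also leaves open whether the same holds with the amide link of compound 1.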